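Two Limits, One Bromine, and an Open Question

The source may report more compounds than this note shows. Statements on the series, on what has been measured and on what is new or still open speak of the compounds shown alone.

compound 1 `CC(C)N(Cc1cccc(OCCCCCC(=O)O)c1)C(=O)c1ccc(-c2cccc(-c3ccccc3)c2)cc1`: > 26000 nM
compound 2 `CC(C)N(Cc1cccc(OCCCCCC(=O)O)c1)C(=O)c1ccc(-c2ccc3c(c2)OCCO3)cc1`: > 21900 nM

In an ADME assay on HEK293 cells (Homo sapiens) for cytotoxicity, read by CellTiter-Glo and resazurin assay, with a stated time of 72 h (on this read-out higher numbers stand for an effect only at larger amounts of compound and lower numbers for an effect already at smaller amounts), compound 1 gives only a limit, > 26000 nM. Compound 2 likewise gives only a limit, > 21900 nM. Both values shown are limits, so compound 2 stands at the edge of what this assay reports, with nothing to rank it against. The step that the two limits leave unreadable from compound 1 to compound 2 cannot be read because both ends sit at limits the limit of > 21900 nM in this assay, at which 1 of the 2 values shown sits (the limit of > 26000 nM in this assay, at which 1 of the 2 values shown sits).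

Compound 3 `CC(C)N(Cc1cccc(OCCCCCC(=O)O)c1)C(=O)c1ccc(-c2cccc(Br)c2)cc1` differs from compound 2 by 3-bromophenyl in place of 2,3-dihydro-1,4-benzodioxin-6-yl on an aromatic carbon. Only the unreadable step from compound 1 to compound 2 bears on this change, and it gives no direction and no size. With nothing pointing to an effect at smaller amounts, compound 3 is expected to give 30000 nM in this assay, in a range from 15000 nM to 60000 nM. The estimated step that the limit leaves unreadable from compound 2 to compound 3 is therefore expected to stay within the scatter, most likely as another limit.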

Compound 3, half-maximal effective concentration: > 26000 nM
Compound 3: no number, only a limit; the forecaster's own chance of this, stated with the estimate: 80%; the middle value is on the limit's open side.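

In this assay compound 3 gives only a limit, > 26000 nM. For the compounds shown here, no step from compound 1 or compound 2 to compound 3 can therefore be read. The compounds shown leave open whether exchanging these groups on the shared core changes cytotoxicity at all, and at what amount any of the three would show an effect.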